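A few compounds are considered here, and "the series" means these few. Any claim that something is new, unique, unknown or untested is made for them only; others in the source may bear on it.

Compound 1 `O=C(COc1ccc2c(=O)ccoc2c1)Nc1cccc(NC(=O)c2ccccc2)c1` gives 120 nM in an assay on isolated protein for inhibition of Rho-associated protein kinase 1 (Homo sapiens), read by scintillation counting, radiometric assay and 33P incorporation, with a stated time of 40 min, in the presence of a further agent that is not named here; on this read-out higher numbers stand for weaker inhibition and lower numbers for stronger inhibition.
Compound 2 `CCCc1ccc(C(=O)Nc2cccc(NC(=O)COc3ccc4c(=O)ccoc4c3)c2)cc1` gives 143 nM in this assay.
Compound 3 `O=C(COc1ccc2c(=O)ccoc2c1)Nc1cccc(NC(=O)c2cnc(C(F)(F)F)s2)c1` gives 160 nM in this assay.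

Compound 3 has the highest of the three numbers, but its distance to the others is small: the step of a 1.3-fold higher number from compound 1 to compound 3 (0.12 log units; within the scatter) and the step of a 1.1-fold higher number from compound 2 to compound 3 (0.05 log units; within the scatter) both lie within the scatter, as does the step of a 1.2-fold higher number from compound 1 to compound 2 (0.08 log units; within the scatter). The three compounds share a core and differ only in the group on the carbonyl carbon of the second amide.

Compound 4 `NCc1ccc(C(=O)Nc2cccc(NC(=O)COc3ccc4c(=O)ccoc4c3)c2)cc1` continues this series with a change in the same place: 4-(aminomethyl)phenyl in place of 2-(trifluoromethyl)-1,3-thiazol-5-yl on a carbonyl carbon. Within the data shown here, the steps that bear on this change are those that alter the group on the carbonyl carbon, from compound 1 to compound 3 and from compound 2 to compound 3, and neither moved the number beyond the scatter. On that basis compound 4 is expected to show a step of a 1.1-fold lower number from compound 3 to compound 4 (0.06 log units; within the scatter), no more than the scatter. Compound 4 is estimated at 140 nM, within a range of 60 nM to 330 nM.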

Compound 4, half-maximal inhibitory concentration: 532 nM
Beside the measured number, compound 4's estimate is 3.8-fold (0.58 log units) below it, and the stated range ends below it.
By their numbers in this assay, from the lowest: compounds 1, 2 and 3 (each within the scatter of the next); then compound 4.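

In this assay, among these compounds, the group on the carbonyl carbon proves not to be indifferent: 4-(aminomethyl)phenyl gives a 3.3-fold higher number from compound 3 to compound 4 (0.52 log units; beyond the scatter), the first step at this position that lies beyond the scatter, and the same holds for a 3.7-fold higher number from compound 2 to compound 4 (0.57 log units; beyond the scatter) and a 4.4-fold higher number from compound 1 to compound 4 (0.65 log units; beyond the scatter). Propyl on the same ring had left the number within the scatter of compound 1, so among these compounds the weaker inhibition goes with aminomethyl and not with the mere presence of a group on the ring. Nothing available explains this loss of inhibition.

The compounds shown leave open whether the step belongs to the amine or to the chain that carries it; a hydroxymethyl group, a 2-aminoethyl chain or a carboxylic acid on the same ring would separate these. They also leave open whether a dimethylamino group would behave like the primary amine.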